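The source may hold more compounds than are shown below. What is called first, only, known or untested is meant among the compounds shown, and "the series" means these compounds.

Measured so far:
Compound 1 `NCCOc1ccc([C@H]2CC[C@]3(CC2)OOC2(O3)C3CC4CC(C3)CC2C4)cc1`: 1370 ng.h/mL
Compound 2 `CC(C)(O)CN1CCC(Oc2ccc([C@H]3CC[C@]4(CC3)OOC3(O4)C4CC5CC(C4)CC3C5)cc2)CC1`: 14200 ng.h/mL

In an ADME assay on the whole organism (strain FVB) for pharmacokinetics, with Mus musculus as the target, read by LC-MS, at a dose of 30 mg/kg by the oral route (a higher number here means more compound in the circulation at the dose given, a lower number less compound in the circulation), compound 1 gives 1370 ng.h/mL, the lower of the two numbers available. Compound 3 `CC(C)(N)CCOc1ccc([C@H]2CC[C@]3(CC2)OOC2(O3)C3CC4CC(C3)CC2C4)cc1` keeps the core of compound 1 and differs from it in one place: 1-amino-1-methylethyl in place of amino on a saturated chain carbon, two bonds along the chain from an oxygen on an aromatic ring. Here 1-amino-1-methylethyl stands in place of amino on a saturated chain carbon, two bonds along the chain from an oxygen on an aromatic ring.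

Within the data shown here, only one measured step bears on this change, and only indirectly. It is the large 10-fold higher number from compound 1 to compound 2 (1.02 log units; beyond the scatter), where 1-(2-hydroxy-2-methylpropyl)piperidin-4-yl replaces 2-aminoethyl on an oxygen on an aromatic ring. That step shows that the number in this assay can move when this part of compound 1 is altered, but it involves a different group, and a single step sets no pattern. A rise is therefore expected for compound 3, though a smaller one, and it may stay close to the scatter. The expected change is a 2.6-fold higher number from compound 1 to compound 3 (0.41 log units; beyond the scatter). Compound 3 is estimated at 3500 ng.h/mL, with an expected range of 1200 ng.h/mL to 10000 ng.h/mL.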

Compound 3, area under the concentration-time curve: 12300 ng.h/mL
Beside the measured number, compound 3's estimate is 3.5-fold (0.55 log units) below it; measured number outside the range, above it.
By their numbers in this assay, from the lowest: compound 1; then compounds 3 and 2 (each within the scatter of the next).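

In this assay, the change from amino to 1-amino-1-methylethyl on a saturated chain carbon, two bonds along the chain from an oxygen on an aromatic ring, gives a 9.0-fold higher number from compound 1 to compound 3 (0.95 log units; beyond the scatter), so a change that brings in no ring is enough to move the number beyond the scatter at this position. The piperidin-4-yl ring of compound 2 is therefore not required for a number of this size: a 1.2-fold lower number from compound 2 to compound 3 (0.06 log units; within the scatter), and this assay does not separate the 3-amino-3-methylbutyl chain from the 1-(2-hydroxy-2-methylpropyl)piperidin-4-yl group on the oxygen on an aromatic ring. No measurement given here accounts for why the number moves with either change.

From the compounds shown here alone, whether 1-aminoethyl or dimethylamino in the same place would give a similar number remains open, as does what a carboxylic acid there would do. All three numbers also come from this assay alone, so they leave open how these compounds would compare at another dose or by another route.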